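Enlarging the amide substituent of a fluorinated naphthalene amide

This account rests on a few compounds, and the source may have more. Where it says the series, first, only, none or still open, it means among the compounds named here.

Of the compounds shown here, two sharing a core have been measured in an assay on LtK cells with ATP-sensitive inward rectifier potassium channel 11 (Homo sapiens) as the target; on this read-out lower numbers stand for an effect already at smaller amounts and higher numbers for an effect only at larger amounts of compound. Compound 1, `CC(=O)Nc1c(C(O)(C(F)(F)F)C(F)(F)F)ccc2ccccc12`, carries a methyl group on the carbonyl carbon of its amide; in this assay compound 1 gives 18 nM. Compound 2, `O=C(Nc1c(C(O)(C(F)(F)F)C(F)(F)F)ccc2ccccc12)C1CCCC1`, carries a cyclopentyl group in the same place instead, and in this assay compound 2 gives 495 nM. Among the measured compounds shown here, the one step that links them, a 28-fold higher number from compound 1 to compound 2 (1.44 log units; beyond the scatter), shows that replacing the small methyl by the larger cyclopentyl moved the number far upward. Among the two numbers known so far, compound 2 therefore stands highest, with compound 1 well apart from it.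

Compound 3, `O=C(CCc1ccccc1)Nc1c(C(O)(C(F)(F)F)C(F)(F)F)ccc2ccccc12`, takes the enlargement one stage further: phenethyl in place of cyclopentyl on a carbonyl carbon. For the measured compounds named here, the only measured step that bears on this change is the one from compound 1 to compound 2, which was large and upward, so a larger group on this carbonyl carbon has so far gone with a higher number. On that basis, compound 3 is expected to give about 900 nM, with a plausible range from 250 nM to 4000 nM. The step this estimate implies, a 1.8-fold higher number from compound 2 to compound 3 (0.26 log units; within the scatter), is expected to be modest and not clearly beyond the scatter.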

Compound 3, half-maximal effective concentration: 1750 nM
For compound 3 the middle estimate is 1.9-fold (0.29 log units) below the measured one, within the range that was stated.
By their numbers in this assay, from the lowest: compound 1; then compound 2; then compound 3.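

In this assay, the climb does not stop at cyclopentyl: putting phenethyl in its place on the carbonyl carbon gives a 3.5-fold higher number from compound 2 to compound 3 (0.55 log units; beyond the scatter), a modest step, yet one that clears the usual scatter. Measured from the small methyl group, the whole enlargement comes to a 97-fold higher number from compound 1 to compound 3 (1.99 log units; beyond the scatter), a large step, so the number rises in the order methyl, cyclopentyl, phenethyl, and none of the three compounds goes against that order. No available measurement explains this rise.

Phenethyl differs from cyclopentyl in more than one way at once, with an aromatic ring in place of a non-aromatic one and a chain leading to that ring, so these compounds cannot say which of these features goes with the higher number; a cyclohexyl group or a phenyl group directly on the carbonyl carbon would help separate them. Going by these compounds, it also remains open whether an ethyl group would stay close to compound 1, and whether an amine or a carboxylic acid at the end of a chain here would bring the number back down.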